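Pyridine amide variations on the triazole-indole series

The source may report more compounds than this note shows. Statements on the series, on what has been measured and on what is new or still open speak of the compounds shown alone.

Compound 1 `COc1ccc(Cn2c(CCc3ccccc3)nnc2[C@H](NC(=O)c2ccccn2)c2c[nH]c3ccccc23)cc1` serves as the reference point: in a functional assay on CHO cells for antagonist activity at growth hormone secretagogue receptor type 1 (Homo sapiens) (on this read-out lower numbers stand for stronger inhibition and higher numbers for weaker inhibition), compound 1 gives 12 nM. Compound 2 `COc1ccc(Cn2c(CCc3ccccc3)nnc2[C@H](NC(=O)c2ccncc2)c2c[nH]c3ccccc23)cc1` carries a pyridin-4-yl on the carbonyl carbon instead, but in this assay compound 2 gives "not determined" (no result reported), so there is nothing to set against the value of compound 1. Compound 3 `COc1ccc(Cn2c(CCc3ccccc3)nnc2[C@H](NC(=O)Cc2ccccn2)c2c[nH]c3ccccc23)cc1` is the next member to be tested. The change from compound 2 to compound 3 is (pyridin-2-yl)methyl in place of pyridin-4-yl on a carbonyl carbon. Among the measured compounds shown here, with no measured step between two members that differ in one place, the size of this step is unknown; an effect beyond the scatter in either direction in this assay is possible, and a loss of some activity is the more likely case. Compound 3 is therefore estimated at 40 nM, with a plausible range from 8 nM to 250 nM.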

Compound 3, antagonist equilibrium constant: 6 nM
Beside the measured number, compound 3's estimate is 6.7-fold (0.82 log units) above it, and the stated range ends above it.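

In this assay, among the compounds shown here, the change on the carbonyl carbon from pyridin-2-yl to (pyridin-2-yl)methyl gives a 2.0-fold lower number from compound 1 to compound 3 (0.30 log units; within the scatter) and is the only readable pair so far: this position accepts the (pyridin-2-yl)methyl group with the read-out held within the scatter of compound 1. The change from compound 2 to compound 3 cannot be read, so pyridin-4-yl offers no comparison here. No supporting data bear on why the two pyridin-2-yl groups read alike.

Still open, on these data alone, is how far the chain on the carbonyl carbon can run, for instance with 2-(pyridin-2-yl)ethyl, and whether (pyridin-4-yl)methyl or pyridin-3-yl reads like the pyridin-2-yl pair. Also open, as far as these compounds go, is whether the pyridine ring is needed at all, which a benzyl or a (dimethylamino)methyl group on the same carbonyl carbon would test.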